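Ester Series: Chloro for Trifluoromethyl on the Benzoate

The source may report more compounds than this note shows. Statements on the series, on what has been measured and on what is new or still open speak of the compounds shown alone.

Compound 1 `COc1cccc(C(=O)Oc2cc3c(cc2C)[C@@H](C(C)C)CC=C3C)c1` gives 24.2% in a functional assay on SK-LU-1 cells (Homo sapiens) for antiproliferative activity, read by sulforhodamine B assay, with a stated time of 48 h, tested at 50 uM; on this read-out lower numbers stand for less inhibition and higher numbers for more inhibition at the one concentration tested (going by the name of the read-out). Compound 2 `CC1=CC[C@H](C(C)C)c2cc(C)c(OC(=O)c3ccc(C(F)(F)F)cc3)cc21` is reported in this assay as "not active" (no number reported), with no number behind it, so no single value places compound 2 against compound 1. Compound 3 `CC1=CC[C@H](C(C)C)c2cc(C)c(OC(=O)c3ccc(Cl)cc3)cc21` differs from compound 2 by chloro in place of trifluoromethyl on an aromatic carbon. Among the compounds with values here, no measured pair shows this step, so the expected shift in this assay is none beyond the usual scatter, in either direction. With compound 2 reported as "not active" (no number reported), compound 3 is expected to sit low in this assay, estimated at 12% within 0% to 30%.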

Compound 3, a percentage reported as inhibition, at one concentration (the size of the read-out at that concentration, not a potency): 17.4%
Beside the measured number, compound 3's estimate is 5.4 percentage points below it; the range from low to high includes it.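

In this assay compound 3, with chloro para to a large group, carries a measured 17.4%, whereas compound 2 has no number, so the step between them cannot be read as a size. The 4-chlorophenyl in place of 3-methoxyphenyl gives a number 6.8 percentage points lower from compound 1 to compound 3 (within the scatter), which leaves these two esters unseparated. Nothing on hand explains either result.

Open, going by these compounds, is whether an amine or a carboxylic acid in place of chloro on that aromatic carbon would shift the inhibition. Also open, on these data alone, is whether an amide linkage in place of the ester would keep it.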